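Chloro for hydrogen on the aryl of compound 1

The compounds below may be only part of what the source reports. "The series", "measured", "known", "first", "only" and "open" are said of these compounds alone.

Measured so far in a functional assay on CHO cells for agonist activity at Free fatty acid receptor 1 (Homo sapiens), read by FLIPR and calcium flux, in the presence of a further agent that is not named here; on this read-out lower numbers stand for an effect already at smaller amounts and higher numbers for an effect only at larger amounts of compound:
compound 1, `O=C(O)CCc1ccc(OCc2nc(-c3ccccc3)no2)cc1`: 1130 nM
compound 2, `O=C(O)CCc1ccc(OCc2noc(-c3ccccc3)n2)cc1`: 2650 nM

Compound 1 holds the lowest of the two numbers in this assay. Compound 2 sits at a higher number, and the gap between the two values lies beyond the usual scatter. For the measured compounds named here, no structural step between the two measured compounds is recorded here, so the comparison rests on the two values alone; both carry the same acid-bearing chain and the same ether link, and differ only in the shared core.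

Compound 3, `O=C(O)CCc1ccc(OCc2nc(-c3ccc(Cl)cc3)no2)cc1`, is not yet measured. It differs from compound 1 by chloro in place of hydrogen on an aromatic carbon.

Going by the values given here, no step between measured compounds is known that would guide this change. In this assay a small step toward a lower number is expected for compound 3, one that may well stay within the scatter of the value of compound 1. The expected step from compound 1 to compound 3 is a 1.7-fold lower number from compound 1 to compound 3 (0.24 log units; within the scatter). Compound 3 is therefore estimated at 650 nM, with a range of 200 nM to 2200 nM.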

Compound 3, half-maximal effective concentration: 540 nM
Estimate against measurement, compound 3: 1.2-fold (0.08 log units) above; measured number inside the range.
By their numbers in this assay, from the lowest: compound 3; then compound 1; then compound 2.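

In this assay, for the compounds shown here, the change from phenyl to 4-chlorophenyl gives a 2.1-fold lower number from compound 1 to compound 3 (0.32 log units; beyond the scatter) and so provides the first readable single-substituent step, a modest one that lies beyond the scatter. It shows that, on this six-membered aromatic ring of carbon only, the aromatic carbon para to a large group accepts one chlorine atom and that the number moves lower, which compound 1 and compound 2 could not show, as they differ only in the shared core and carry the same unsubstituted phenyl. Nothing measured here bears on the reason for this step.

Going by these compounds, whether the step belongs to chloro specifically or would also appear with fluoro, methyl or methoxy on the same carbon remains open, as does the result of placing chloro on another carbon of this ring. Also open, on these data alone, is whether the same phenyl to 4-chlorophenyl change on the core of compound 2 would give a step of similar size, which would show whether the gain carries across both cores.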